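Compound 1 to compound 4: replacing one group

The source may hold more compounds than are shown below. What is called first, only, known or untested is meant among the compounds shown, and "the series" means these compounds.

In an ADME assay on microsomes from liver (Homo sapiens) for metabolic stability, read by LC-MS, using NADPH, with stated times of 5 min and 30 min, tested at 1 uM (a higher number here means faster removal of the compound, a lower number slower removal), compound 1 `O=C1c2ccccc2CN1c1cnc(NCc2c(F)ccc3c2CCO3)n2cnnc12` gives 13 mL.min-1.g-1 and lies within the scatter of the two other measured compounds. These are compound 2 `CN(C)Cc1ccc2c(c1)CN(c1cnc(NCc3c(F)ccc4c3CCO4)n3cnnc13)C2=O` at 19 mL.min-1.g-1 and compound 3 `Cc1cc(-c2cnc(NCc3c(F)ccc4c3CCO4)c3cn[nH]c(=O)c23)n(C)n1` at 24 mL.min-1.g-1 in the same measurement. Within the data shown here, the three values therefore set no order among the compounds.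

Compound 4 `CN(C(=O)c1ccccc1)c1cnc(NCc2c(F)ccc3c2CCO3)n2cnnc12` keeps the core of compound 1 and changes one substituent: a group of 10 heavy atoms (8 carbon, 1 nitrogen, 1 oxygen; one six-membered aromatic ring of carbon only) in place of a group of 10 heavy atoms (8 carbon, 1 nitrogen, 1 oxygen; one five-membered non-aromatic ring with 1 hetero atom, one six-membered aromatic ring of carbon only), on an aromatic carbon with benzoyl(methyl)amino as the entering group. The five-membered non-aromatic ring of compound 1 leaves with the old group.

Among the measured compounds shown here, the one measured step (a 1.5-fold higher number from compound 1 to compound 2 (0.16 log units; within the scatter)) places (dimethylamino)methyl in place of hydrogen on an aromatic carbon. That is a different change from this one, and it stays within the scatter. For the measured compounds named here, no measured step covers the replacement in compound 4 directly, so the evidence is indirect and a step beyond the scatter is not expected.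

The estimated change, a small one toward a higher number, is a 1.4-fold higher number from compound 1 to compound 4 (0.14 log units; within the scatter) and is expected to stay within the scatter. For compound 4 the estimated value is 18 mL.min-1.g-1 with an expected range from 9 mL.min-1.g-1 to 36 mL.min-1.g-1 in this assay.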

Compound 4, intrinsic clearance in microsomes: > 300 mL.min-1.g-1
Compound 4: only a limit was reported; the forecaster's own chance of this, stated with the estimate: 2%; middle value at least 16-fold (1.22 log units) away from the limit.
By their numbers in this assay, from the lowest: compounds 1, 2 and 3 (each within the scatter of the next). At a limit, above all of these: compound 4.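

At this position, on the aromatic carbon para to a large group, the choice of group has a large effect in this assay: benzoyl(methyl)amino in place of the group of compound 1 gives an at least 23-fold higher number from compound 1 to compound 4 (1.36 log units; beyond the scatter). The earlier step, a 1.5-fold higher number from compound 1 to compound 2 (0.16 log units; within the scatter), stays within the scatter, so only the new step shows that the series can move beyond it, and it does so through a change at this place in the molecule rather than through (dimethylamino)methyl on the aromatic ring of the old group. Compound 4 stands at a limit of the assay, not at a number: the limit of > 300 mL.min-1.g-1 in this assay, at which 1 of the 4 values shown sits.

The two groups agree in every count computed for them, and the visible difference is the five-membered non-aromatic ring that leaves, yet the compounds shown do not separate the loss of that ring from the presence of the methyl on the entering group. Open too, going by these compounds, is how benzoylamino, with hydrogen in place of that methyl, or acetyl(methyl)amino, without the aromatic ring, would stand in this assay.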